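Bromination of the quinone ring in compound 2

The compounds below may be only part of what the source reports. "The series", "measured", "known", "first", "only" and "open" are said of these compounds alone.

The three measured compounds share a core in which an aminonaphthoquinone is tethered to a sulfonyl amidine. Compound 1 `COc1ccc(N/C(CCNC2=CC(=O)c3ccccc3C2=O)=N\S(=O)(=O)c2ccc(C)cc2)cc1` gives 7590 nM in a functional assay on HeLa cells (Homo sapiens) for cytotoxicity, read by MTT assay, with a stated time of 48 h; on this read-out higher numbers stand for weaker inhibition and lower numbers for stronger inhibition. Compound 2 `COc1ccc(N/C(CCNC2=CC(=O)c3ccccc3C2=O)=N\S(=O)(=O)c2ccc(C)cc2)cc1OC` gives 14500 nM in this assay, and compound 3 `Cc1ccc(S(=O)(=O)/N=C(/CCNC2=CC(=O)c3ccccc3C2=O)Nc2ccc(Cl)cc2Cl)cc1` gives 20500 nM. Compound 2 thus stands second highest of the three numbers, with a 1.9-fold higher number from compound 1 to compound 2 (0.28 log units; within the scatter) on one side and a 1.4-fold higher number from compound 2 to compound 3 (0.15 log units; within the scatter) on the other, so that all three values sit within the scatter of one another; only a 2.7-fold higher number from compound 1 to compound 3 (0.43 log units; beyond the scatter) reaches beyond it.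

Compound 4 `COc1ccc(N/C(CCNC2=C(Br)C(=O)c3ccccc3C2=O)=N\S(=O)(=O)c2ccc(C)cc2)cc1OC` differs from compound 2 by bromo in place of hydrogen on a double-bonded ring carbon. Among the measured compounds shown here, none of the measured steps touches this part of the molecule: each of them alters the aryl group on the amine nitrogen, and the ring carbon that takes the bromo remains unchanged across compounds 1, 2 and 3. For the measured compounds named here, no measured step therefore bears on the change from compound 2 to compound 4, and no direction can be inferred from the data. For compound 4 a step of no change at the digits printed from compound 2 to compound 4 (within the scatter) is expected, meaning none beyond the scatter. Compound 4 is estimated at 14500 nM, with a range from 5000 nM to 40000 nM.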

Compound 4, half-maximal inhibitory concentration: 5370 nM
For compound 4 the middle estimate is 2.7-fold (0.43 log units) above the measured one; measured number inside the range.
By their numbers in this assay, from the lowest: compounds 4, 1, 2 and 3 (each within the scatter of the next, the first and the last beyond it).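

The earlier compounds shown here varied only the aryl group on the amine nitrogen, so they gave no reading of the double-bonded ring carbon. In this assay, compound 4 shows that this place is sensitive to substitution, with a 2.7-fold lower number from compound 2 to compound 4 (0.43 log units; beyond the scatter), a modest step toward stronger inhibition on bromo in place of hydrogen. No measurement available here accounts for this step.

The compounds shown leave open whether the step is particular to bromo or would also appear with chloro, a methyl group or an amine on the same ring carbon. They also leave open whether bromo gives a step of similar size when the amine nitrogen carries the 4-methoxyphenyl or 2,4-dichlorophenyl group instead.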